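From methyl to 4-methoxycyclohexyl on an aromatic nitrogen

The source may report more compounds than this note shows. Statements on the series, on what has been measured and on what is new or still open speak of the compounds shown alone.

Measured so far in a functional assay on LNCaP cells (Homo sapiens) for cytotoxicity; a lower number here means a stronger inhibitor, a higher number a weaker inhibitor:
Compound 1 `CNC(=O)Nc1ccc(-c2nc(N3CC4CCC(C3)O4)c3cnn(C)c3n2)cc1` gives 170 nM
Compound 2 `O=C(Nc1ccc(-c2nc(N3CC4CCC(C3)O4)c3cnn(C4CCC5(CC4)OCCO5)c3n2)cc1)NC1CC1` gives 2 nM

Of these two compounds, compound 1 has the higher number, and the gap down to compound 2 lies beyond the scatter of the measurement. Compound 3 `CNC(=O)Nc1ccc(-c2nc(N3CC4CCC(C3)O4)c3cnn([C@H]4CC[C@H](OC)CC4)c3n2)cc1` has not yet been tested. It departs from compound 1 in one place, with 4-methoxycyclohexyl in place of methyl on an aromatic nitrogen in all. Within the data shown here, no measured pair isolates this change, so its size has no direct measure. Compound 2 is the nearest guide: it also has a six-membered non-aromatic ring on that nitrogen, and compound 2 reaches 2 nM in this series, but it differs elsewhere as well. A step towards a lower number in this assay, beyond the scatter, is therefore expected, though probably not all the way to the value of compound 2. The expected shift is estimated as a 6.8-fold lower number from compound 1 to compound 3 (0.83 log units; beyond the scatter) for now. The estimate for compound 3 is 25 nM, with an expected range from 5 nM to 120 nM.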

Compound 3, half-maximal inhibitory concentration: 2 nM
Compound 3: middle estimate off by 13-fold (1.10 log units), on the high side, and the stated range ends above it.
By their numbers in this assay, from the lowest: compounds 2 and 3 (each within the scatter of the next); then compound 1.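

In this assay, replacing the methyl on an aromatic nitrogen with 4-methoxycyclohexyl, with the rest of the molecule unchanged, brings an 85-fold lower number from compound 1 to compound 3 (1.93 log units; beyond the scatter) and so counts as a large step. Among these compounds, until this result, the only low value belonged to compound 2, which also differs from compound 1 elsewhere, so the contribution of this position could not be isolated; this single change now shows that the group on this nitrogen can by itself move the value by a large margin, and that a substituent of 8 heavy atoms with a six-membered non-aromatic ring is compatible with a low value here. Nothing available explains why the change has so large an effect on this result.

What the compounds shown leave open is how the step divides between the cyclohexyl ring and its methoxy group, a question that plain cyclohexyl or 4-hydroxycyclohexyl on the same nitrogen would address. Also open, as far as these compounds go, is whether the defined stereocentres matter, which the other stereoisomer of 4-methoxycyclohexyl could settle, and whether an open chain such as n-hexyl or a ring amine such as piperidin-4-yl would serve equally well at this position.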